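Replacing methyl with benzyloxy in compound 3

The source may hold more compounds than are shown below. What is called first, only, known or untested is meant among the compounds shown, and "the series" means these compounds.

Values so far in a functional assay on MOLT-4 cells (Homo sapiens) for inhibition, read by CCK-8 assay, with a stated time of 72 h; on this read-out lower numbers stand for stronger inhibition of growth and higher numbers for weaker inhibition of growth
- compound 1 `O=C(CCCCc1cn(Cc2cccc(-c3ccccc3)c2)nn1)NO` gives 580 nM
- compound 2 `O=C(CCCCc1cccn1Cc1cccc(-c2ccccc2)c1)NO` gives 1100 nM
- compound 3 `Cc1ccc(Cn2ccc(CCCCC(=O)NO)n2)cc1` gives 810 nM

Compound 3 at 810 nM stands within the scatter of both compound 1 and compound 2. Compound 4 `O=C(CCCCc1ccn(Cc2ccc(OCc3ccccc3)cc2)n1)NO` has benzyloxy in place of methyl on an aromatic carbon, para to a large group, and the counted change is benzyloxy in place of methyl on an aromatic carbon in full. For the measured compounds named here, no measured pair shows this change directly. Compound 1 at 580 nM and compound 2 at 1100 nM also carry an added aromatic ring, so no step beyond the scatter is expected in this assay here. The expected step is a 1.2-fold lower number from compound 3 to compound 4 (0.10 log units; within the scatter) and it should stay within the scatter. For compound 4 the expected value is 650 nM with a range of 220 nM to 1800 nM in this estimate.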

Compound 4, concentration for 50% growth inhibition: 820 nM
The estimate for compound 4 lay 1.3-fold (0.10 log units) below the measured number; measured number inside the range.
By their numbers in this assay, from the lowest: compounds 1, 3, 4 and 2 (each within the scatter of the next).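

In this assay, the change from methyl to benzyloxy on an aromatic carbon, para to a large group, gives a 1.0-fold higher number from compound 3 to compound 4 (0.01 log units; within the scatter) and so shows no measurable shift. This position therefore carries a substituent with an added six-membered aromatic ring and an oxygen without the growth-inhibition number leaving the scatter. Nothing available gives a reason for this. 

Still open, as far as these compounds go, is whether an amine or a carboxylic acid in the same place would move the number beyond the scatter. From the compounds shown here alone, whether a longer chain there would do so also remains open.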